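The source may report more compounds than this note shows. Statements on the series, on what has been measured and on what is new or still open speak of the compounds shown alone.

Measured so far in a physicochemical assay for solubility, read by spectrophotometry, in phosphate buffer, with a stated time of 18 h, at pH 7.4; on this read-out lower numbers stand for lower solubility and higher numbers for higher solubility:
- compound 1, `CCc1ccc(-c2nc3c(c(C)nn3-c3ccccc3)c(-c3ccccc3F)c2C#N)cc1`: 1700 nM
- compound 2, `CCc1ccc(-c2nc3c(c(C)nn3-c3ccccc3)c(-c3ccccc3C(F)(F)F)c2C#N)cc1`: 11000 nM
- compound 3, `Cc1nn(-c2ccccc2)c2nc(-c3ccc(C(F)(F)F)cc3)c(C#N)c(-c3ccccc3O)c12`: 3500 nM

Compound 2 and compound 1 differ in one place, (fluoro in place of trifluoromethyl on an aromatic carbon), and the step is a 6.5-fold lower number from compound 2 to compound 1 (0.81 log units; beyond the scatter). Compound 3 stands second highest of the three; against compound 1 it is higher, against compound 2 lower, both gaps beyond the scatter. The difference between the core of compound 3 and the core of compound 2 is not broken down here.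

Compound 4, `Cc1nn(-c2ccccc2)c2nc(-c3ccc(F)cc3)c(C#N)c(-c3ccccc3O)c12`, is not yet measured. It differs from compound 3 by fluoro in place of trifluoromethyl on an aromatic carbon. This is the same kind of change as that from compound 2 to compound 1, but not the same: there the fluoro sits ortho to a large group, here para to a large group, and the rest of the molecule also differs. Among the compounds with values here, the one known step of this kind runs toward a lower number: a 6.5-fold lower number from compound 2 to compound 1 (0.81 log units; beyond the scatter). Within the data shown here, the step from compound 3 to compound 4 is expected to run in the same direction, but is estimated at a smaller size, a 2.9-fold lower number from compound 3 to compound 4 (0.46 log units; beyond the scatter), since only one such step is known and it sits on a different core. On that basis compound 4 is expected to give about 1200 nM in this assay, with an estimated range from 500 nM to 3500 nM.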

Compound 4, solubility: 6000 nM
Compound 4: middle estimate off by 5.0-fold (0.70 log units), on the low side, outside the stated range (above it).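

In this assay the change from trifluoromethyl to fluoro gives a 6.5-fold lower number from compound 2 to compound 1 (0.81 log units; beyond the scatter) and, on the other core, a 1.7-fold higher number from compound 3 to compound 4 (0.23 log units; within the scatter) as its second reading, so the sizeable step seen on the first core did not carry over to the core of compound 3. Within the data shown here, this does not show that the change is without consequence across the series, since there is only one pair on each core, and the two pairs differ both in where the change sits and in the rest of the molecule, so neither difference can be singled out. No supporting measurement bears on why the two steps part.

As far as these compounds go, it stays open how a methoxy group or an amine at the same place on the core of compound 3 would read, and whether a carboxylic acid there would stand apart from compound 3 and compound 4. Also open, from the compounds shown here alone, is whether the contrast follows the place of the change or the core, which a pair with the change at the other place on one core would help to settle.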